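The source may hold more compounds than are shown below. What is called first, only, known or untested is meant among the compounds shown, and "the series" means these compounds.

Compound 1 `C[C@H]1CC[C@@H]2[C@@H](OC(=O)[C@]23CC(c2ccccc2Br)=NO3)[C@]2(C)C(=O)C=C[C@@]12O` and compound 2 `C[C@H]1CC[C@@H]2[C@@H](OC(=O)[C@]23CC(c2ccccc2Cl)=NO3)[C@]2(C)C(=O)C=C[C@@]12O` share one core and differ in one place only: chloro in place of bromo on an aromatic carbon. In a physicochemical assay for lipophilicity (a higher number here means a more lipophilic compound, a lower number a more polar compound), compound 1 gives 2.22, and compound 2 gives 2.09; the step of a number 0.13 log units lower from compound 1 to compound 2 (within the scatter) is what this single exchange made on that core. Compound 3 `C[C@H]1CC[C@@H]2[C@@H](OC(=O)[C@]23CC(c2ccc(Br)cc2)N(c2ccccc2)O3)[C@]2(C)C(=O)C=C[C@@]12O` carries a different core, and how the two cores differ is not broken down here; in this assay compound 3 gives 4, the highest of the three values, well apart from both compound 1 and compound 2. Compound 4 `C[C@H]1CC[C@@H]2[C@@H](OC(=O)[C@]23CC(c2ccc(Cl)cc2)N(c2ccccc2)O3)[C@]2(C)C(=O)C=C[C@@]12O` is related to compound 3 by the same kind of change, (chloro in place of bromo on an aromatic carbon), though the place is not the same: in compound 1 the halogen sits ortho to a large group, in compound 3 para to a large group. Compound 4 has not yet been measured in this assay. Because the earlier exchange gave a number 0.13 log units lower from compound 1 to compound 2 (within the scatter), the step from compound 3 to compound 4 is expected to be small, a number 0.12 log units lower from compound 3 to compound 4 (within the scatter). Compound 4 is therefore estimated at 3.88, with a range from 3.6 to 4.2.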

Compound 4, partition coefficient: 3.87
Estimate against measurement, compound 4: 0.01 log units above; low and high end bracket the measured number.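

In this assay, chloro in place of bromo gave a number 0.13 log units lower from compound 3 to compound 4 (within the scatter), and on the other core the same exchange gave a number 0.13 log units lower from compound 1 to compound 2 (within the scatter). The exchange therefore stayed within the scatter on both cores, even though the halogen sits at a different place on each, and in this pair of cores a small step carried over from one to the other. It does not show that the two steps reflect one shared effect or that the result holds beyond these four compounds, and nothing given here bears on what lies behind it.

The compounds shown carry only bromo or chloro at this place, so what a methoxy group, an amine or a carboxylic acid would do there on either core remains open. Also open, on these data alone, is whether moving the halogen to another place on the same core would change the reading.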